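Shortening the phenylalkyl amide chain on a shared core

The compounds below may be only part of what the source reports. "The series", "measured", "known", "first", "only" and "open" are said of these compounds alone.

Compound 1 `CCCC(=O)Nc1ccc(N2CCN(c3ccc(OC[C@@H]4CO[C@@](Cn5cncn5)(c5ccc(Cl)cc5Cl)O4)cc3)CC2)cc1` gives 2990 nM in a functional assay on A549 cells (Homo sapiens) for inhibition, read by MTT assay, with a stated time of 48 h; a lower number here means a stronger inhibitor, a higher number a weaker inhibitor.
Compound 2 `O=C(CC1CCOCC1)Nc1ccc(N2CCN(c3ccc(OC[C@@H]4CO[C@@](Cn5cncn5)(c5ccc(Cl)cc5Cl)O4)cc3)CC2)cc1` gives 10000 nM in this assay.
Compound 3 `O=C(CCCCc1ccccc1)Nc1ccc(N2CCN(c3ccc(OC[C@@H]4CO[C@@](Cn5cncn5)(c5ccc(Cl)cc5Cl)O4)cc3)CC2)cc1` gives 2610 nM in this assay.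

Compound 3 has the lowest of the three numbers, but its gap to compound 1 is within the scatter, a 1.1-fold lower number from compound 1 to compound 3 (0.06 log units; within the scatter), so the two cannot be ordered; only compound 2 stands apart, a 3.8-fold lower number from compound 2 to compound 3 (0.58 log units; beyond the scatter). Compound 4 `O=C(CCc1ccccc1)Nc1ccc(N2CCN(c3ccc(OC[C@@H]4CO[C@@](Cn5cncn5)(c5ccc(Cl)cc5Cl)O4)cc3)CC2)cc1` differs from compound 3 in one place: phenyl in place of phenethyl on a saturated chain carbon, two bonds along the chain from a carbonyl carbon. For the measured compounds named here, no measured step is a direct analogue of cutting two carbons from this chain. The closest evidence is the step from compound 1 to compound 3, where a much longer phenyl-bearing chain left the number essentially unchanged, which suggests the length of this chain matters little in this assay. Compound 2 shows that a branched oxanyl substituent at the chain carbon next to the carbonyl is less well tolerated, a change of a different kind. Compound 4 is therefore expected to land close to compound 3, with a 1.1-fold higher number from compound 3 to compound 4 (0.06 log units; within the scatter) within the scatter. The estimate for compound 4 in this assay is 3000 nM, with a range from 1300 nM to 7500 nM.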

Compound 4, half-maximal inhibitory concentration: 2060 nM
Estimate against measurement, compound 4: 1.5-fold (0.16 log units) above, within the range that was stated.
By their numbers in this assay, from the lowest: compounds 4, 3 and 1 (each within the scatter of the next); then compound 2.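

For the compounds shown here, exchanging phenethyl for phenyl, two bonds along the chain from a carbonyl carbon, gives no step that can be told from the scatter in this assay (a 1.3-fold lower number from compound 3 to compound 4 (0.10 log units; within the scatter)), and compound 4 also cannot be ordered against the plain alkyl amide (a 1.5-fold lower number from compound 1 to compound 4 (0.16 log units; within the scatter)). The gap to the oxan-4-yl compound holds with this shorter phenyl chain as it did with the longer one (a 4.9-fold lower number from compound 2 to compound 4 (0.69 log units; beyond the scatter)), so compounds 1, 3 and 4 form one group and compound 2 stands apart from it. Nothing given here explains why the chain length leaves the number in place or why compound 2 stands apart.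

Going by these compounds, whether an amine or a carboxylic acid at the end of this chain would stay with that group remains open. So does the effect of a fluorine on the phenyl ring of compound 4.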